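A Boc-Protected Chain in Place of a Benzyl Ether

This account rests on a few compounds, and the source may have more. Where it says the series, first, only, none or still open, it means among the compounds named here.

Measured compounds:
compound 1 `Nc1nc(-c2ccccc2)nn1-c1ncnc2cc(Cl)ccc12`: > 40000 nM
compound 2 `COCCOc1cc2ncnc(-n3nc(-c4ccccn4)nc3N)c2cc1OCCOC`: 2300 nM
compound 3 `COc1cc2ncnc(-n3nc(-c4ccccn4)nc3N)c2cc1OCc1ccccc1`: 8600 nM

All three were tested in an assay on MCF7 cells for inhibition of Serine-protein kinase ATM (Homo sapiens), read by immunofluorescence, with a stated time of 1 h; on this read-out lower numbers stand for stronger inhibition and higher numbers for weaker inhibition. For compound 1 the result is only a limit, > 40000 nM, not a number; this is the limit of > 40000 nM in this assay, at which 1 of the 3 values shown sits. Compound 2 gives 2300 nM in this assay. Compound 3 gives 8600 nM in this assay, the higher of the two numbers shown, with compound 2 sitting lower by a margin beyond the scatter.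

Compound 4 `COc1cc2ncnc(-n3nc(-c4ccccn4)nc3N)c2cc1OCCCNC(=O)OC(C)(C)C` differs from compound 3 by 2-((tert-butoxycarbonyl)amino)ethyl in place of phenyl on a saturated chain carbon bound to an oxygen on an aromatic ring. For the measured compounds named here, no measured step of this kind exists. A moderate decrease in the number is expected, toward compound 2, whose chain-bearing ethers gave 2300 nM. For compound 4 the estimated step is a 2.2-fold lower number from compound 3 to compound 4 (0.33 log units; beyond the scatter). Compound 4 is expected at 4000 nM, between 1500 nM and 12000 nM.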

Compound 4, half-maximal inhibitory concentration: 900 nM
Beside the measured number, compound 4's estimate is 4.4-fold (0.65 log units) above it; the measured number lies below the stated range.
By their numbers in this assay, from the lowest: compound 4; then compound 2; then compound 3. At a limit, above all of these: compound 1.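

For the compounds shown here, at the saturated chain carbon bound to an oxygen on an aromatic ring, the earlier compounds offered no change in one place, and compound 4 now supplies one. In this assay, 2-((tert-butoxycarbonyl)amino)ethyl in place of phenyl gives a 9.6-fold lower number from compound 3 to compound 4 (0.98 log units; beyond the scatter) and a step beyond the scatter, so a phenyl ring is not required here for a lower number. Nothing measured here bears on why the number falls.

On these data alone, whether the step belongs to the tert-butoxycarbonyl group or to the chain itself stays open. So does what a free amine at the chain end or a longer chain would give.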